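Compound 1 to compound 3: a hydrogen on the oxygen

The source may report more compounds than this note shows. Statements on the series, on what has been measured and on what is new or still open speak of the compounds shown alone.

- Compound 1 `COc1ccc(OC)c(C2=C(c3cc(OC)c(OC)c(OC)c3)C(=O)CC2O[SiH2]C(C)(C)C)c1` gives 9.5 ug/mL
- Compound 2 `COc1ccc(C2=C(c3cc(OC)c(OC)c(OC)c3)C(=O)CC2O[SiH2]C(C)(C)C)cc1OC` gives > 100 ug/mL as a limit of the assay

Going by the values given here, in an ADME assay on HEK293 cells (Homo sapiens) for cytotoxicity, read by MTT assay, with a stated time of 72 h (a higher number here means a weaker inhibitor, a lower number a stronger inhibitor), compound 1 gives 9.5 ug/mL as the only actual number so far. Among the compounds with values here, the one other value so far is a limit. Compound 3 `COc1ccc(OC)c(C2=C(c3cc(OC)c(OC)c(OC)c3)C(=O)CC2O)c1` differs from compound 1 in one place: a hydrogen atom in place of a group of 5 heavy atoms (4 carbon, 1 silicon; no ring), on an oxygen on a saturated carbon. Within the data shown here, the single measured step, an at least 10-fold higher number from compound 1 to compound 2 (1.02 log units; beyond the scatter), is large but sits on a double-bonded ring carbon, not on this oxygen. It shows that one change can move this series far, but it fixes neither size nor direction here. No step beyond the scatter is firmly expected, only a slight lean towards a higher number, with a wide range. The expected change is a 1.6-fold higher number from compound 1 to compound 3 (0.20 log units; within the scatter). Compound 3 is estimated at 15 ug/mL, with an expected range from 3 ug/mL to 80 ug/mL.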

Compound 3, half-maximal inhibitory concentration: > 100 ug/mL
Compound 3: a limit, no number (the forecaster's own chance of this, stated with the estimate: 20%); middle value at least 6.6-fold (0.82 log units) from the limit.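

At the oxygen on a saturated carbon, the group of 5 heavy atoms (4 carbon, 1 silicon) matters in this assay, and a large step now appears at a second place in the series, not only on the double-bonded ring carbon (an at least 10-fold higher number from compound 1 to compound 3 (1.02 log units; beyond the scatter)). Compound 3 gives > 100 ug/mL, which is a limit of the assay. The step therefore gives a minimum and not a full size, and only compound 1 still carries an actual number: the limit of > 100 ug/mL in this assay, at which 2 of the 3 values shown sit.

From the compounds shown here alone, whether a methyl or an acetyl group on this oxygen gives a number close to that of compound 1, or also ends at the limit, remains open. A longer alkyl chain carrying no silicon would show whether silicon itself is needed at this place.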